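Selenium and tellurium chain sulfates against cell growth

The compounds below may be only part of what the source reports. "The series", "measured", "known", "first", "only" and "open" are said of these compounds alone.

Compound 1, `O=S(=O)(O)OCCCCCCCCCC[Se]c1ccccc1`: in a functional assay on HCT-116 cells (Homo sapiens) for cytotoxicity, read by MTT assay, with a stated time of 24 h (on this read-out lower numbers stand for stronger inhibition and higher numbers for weaker inhibition), compound 1 gives > 100000 nM, which is a limit of the assay and not a number.
Compound 2, `O=S(=O)(O)OCCCCCCCC[Se]c1ccccc1`: in this assay compound 2 gives > 100000 nM, again a limit and not a number.
Within the data shown here, compound 3, `O=S(=O)(O)OCCCCCCCCCCC[Te]c1ccccc1`: in this assay compound 3 gives 9730 nM, the only number in the set.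

The change from compound 1 to compound 2 is sulfooxy in place of 2-(sulfooxy)ethyl on a saturated chain carbon, eight bonds along the chain from a selenium atom. Its step, a step that the two limits leave unreadable from compound 1 to compound 2, cannot be sized, since the limit of > 100000 nM in this assay, at which 2 of the 3 values shown sit, covers both ends of it. How the core of compound 1 differs from that of compound 3 is not broken down here. Compound 4, `O=S(=O)(O)OCCCCCCCCC[Te]c1ccccc1`, has not yet been tested in this assay. It arises from compound 3 by sulfooxy in place of 2-(sulfooxy)ethyl on a saturated chain carbon, nine bonds along the chain from a tellurium atom; this is the same kind of change as that from compound 1 to compound 2, but the place differs: eight bonds along the chain from a selenium atom there, nine bonds along the chain from a tellurium atom here. The measured pair gives no readable size for this kind of change, so the expectation rests only on compound 3. For compound 4 the step of a 1.5-fold higher number from compound 3 to compound 4 (0.19 log units; within the scatter) is expected, staying near the value of compound 3, 9730 nM. Compound 4 is therefore estimated at 15000 nM, expected to lie between 5000 nM and 50000 nM.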

Compound 4, half-maximal inhibitory concentration: 4990 nM
Estimate against measurement, compound 4: 3.0-fold (0.48 log units) above; the measured number lies below the stated range.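

In this assay, sulfooxy in place of 2-(sulfooxy)ethyl on the core of compound 3 gives a 1.9-fold lower number from compound 3 to compound 4 (0.29 log units; within the scatter), so on this core the change has no effect that can be told apart from ordinary variation between repeated measurements. Compound 1 and compound 2 carry the same kind of change on their own core, but each sits at a limit of the assay and not at a number, so their step cannot be read: the limit of > 100000 nM in this assay, at which 2 of the 4 values shown sit. This leaves a single readable pair, which shows that the change is tolerated on one core but cannot show whether it would behave the same way on the other.

How selenium and tellurium compare with the chain held the same stays open, since every pair shown that differs in that atom also differs in its chain. Also open, from the compounds shown here alone, is what a carboxylic acid or an amine would do in place of the sulfooxy group on either core.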